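From 2-Bromobenzyl to 3-Methoxybenzyl on a Shared Core

The source may report more compounds than this note shows. Statements on the series, on what has been measured and on what is new or still open speak of the compounds shown alone.

In a functional assay on CCRF-CEM cells (Homo sapiens) for antiproliferative activity, with a stated time of 72 h (on this read-out lower numbers stand for stronger inhibition and higher numbers for weaker inhibition), compound 1 (`OC[C@H]1O[C@@H](n2cnc3c(NCc4ccc(F)cc4)ncnc32)[C@H](O)[C@@H]1O`) gives 1250 nM, compound 2 (`OC[C@H]1O[C@@H](n2cnc3c(NCc4ccccc4Cl)ncnc32)[C@H](O)[C@@H]1O`) gives 14500 nM and compound 3 (`OC[C@H]1O[C@@H](n2cnc3c(NCc4ccccc4Br)ncnc32)[C@H](O)[C@@H]1O`) gives 12300 nM. Compound 3 sits at the high end of these numbers, with a 1.2-fold lower number from compound 2 to compound 3 (0.07 log units; within the scatter) and a 9.8-fold higher number from compound 1 to compound 3 (0.99 log units; beyond the scatter). Compound 4 (`COc1cccc(CNc2ncnc3c2ncn3[C@@H]2O[C@H](CO)[C@@H](O)[C@H]2O)c1`) carries 3-methoxyphenyl in place of 2-bromophenyl on a saturated chain carbon bound to a nitrogen on an aromatic ring. Among the compounds with values here, no measured compound carries 3-methoxyphenyl, so the closest guides are the steps away from 4-fluorophenyl, including a 12-fold higher number from compound 1 to compound 2 (1.06 log units; beyond the scatter). A moderate move back toward compound 1 is therefore expected, and the estimated change in this assay is a 3.1-fold lower number from compound 3 to compound 4 (0.49 log units; beyond the scatter). Compound 4 is estimated at 4000 nM, with an expected range of 1200 nM to 13000 nM.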

Compound 4, half-maximal inhibitory concentration: 7600 nM
The estimate for compound 4 lay 1.9-fold (0.28 log units) below the measured number; measured number inside the range.
By their numbers in this assay, from the lowest: compound 1; then compounds 4, 3 and 2 (each within the scatter of the next).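

In this assay, the 3-methoxyphenyl group of compound 4 does not separate from the two halogen-bearing groups (a 1.6-fold lower number from compound 3 to compound 4 (0.21 log units; within the scatter); a 1.9-fold lower number from compound 2 to compound 4 (0.28 log units; within the scatter)). It also stays apart from the 4-fluorophenyl group (a 6.1-fold higher number from compound 1 to compound 4 (0.78 log units; beyond the scatter)), so among these compounds, a group without a halogen does not by itself restore the number of compound 1. Nothing available explains these steps. The compounds shown leave open how an unsubstituted phenyl would compare with the 4-fluorophenyl group of compound 1. They also leave open whether an amine or a carboxylic acid on this ring would move the number.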